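This account rests on a few compounds, and the source may have more. Where it says the series, first, only, none or still open, it means among the compounds named here.

Measured in an assay on isolated protein for inhibition of lysosomal alpha-glucosidase (Rattus norvegicus), read by colorimetric assay; on this read-out lower numbers stand for stronger inhibition and higher numbers for weaker inhibition:
Compound 1 `Cc1ccc(S(=O)(=O)Nc2ccc3c(c2)C(=O)N(Cc2ccc(Cl)cc2)C3=O)cc1`: 188000 nM.
Compound 2 `Cc1ccc(S(=O)(=O)Nc2ccc3c(c2)C(=O)N(C)C3=O)cc1`: > 200000 nM, a limit of this assay rather than a number.

Compound 2 therefore stands at the limit of this assay, the weaker end of what was measured; (the limit of > 200000 nM in this assay, at which 1 of the 2 values shown sits). Compound 3 `Cc1ccc(S(=O)(=O)Nc2ccc3c(c2)C(=O)N(Cc2ccccc2)C3=O)cc1` differs from compound 2 by phenyl in place of hydrogen on a saturated chain carbon bound to an amide-type nitrogen in a ring. Among the compounds with values here, the one measured step that bears on this change is an at least 1.0-fold higher number from compound 1 to compound 2 (0.02 log units; that floor lies within the scatter), which runs in the opposite direction and lies within the scatter. Putting an aromatic group back on that carbon is thus expected to move the number by no more than the scatter, a number no higher from compound 2 to compound 3 (the limit leaves the size open). Compound 3 is estimated at 200000 nM, between 90000 nM and 450000 nM, with a real chance that only a limit is reported.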

Compound 3, half-maximal inhibitory concentration: > 200000 nM
Compound 3 gave a limit, no number; the forecaster's own chance of this, stated with the estimate: 50%; the middle value sits exactly at the limit.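

In this assay compound 3 also gives only a limit, > 200000 nM, not a number. Hydrogen in place of chloro on the aromatic carbon reads as an at least 1.0-fold higher number from compound 1 to compound 3 (0.02 log units; that floor lies within the scatter), so no effect of the chloro group separates from the scatter. The step from methyl to benzyl joins two limits and cannot be read, and limits now dominate the series: the limit of > 200000 nM in this assay, at which 2 of the 3 values shown sit.

Left open is whether an amine, a carboxylic acid or a longer chain in place of the benzyl group would take the series clear of compound 1, at 188000 nM.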